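This account rests on a few compounds, and the source may have more. Where it says the series, first, only, none or still open, it means among the compounds named here.

Measured compounds:
- compound 1, `CNc1ccnc(Nc2ccc(Cl)c(OCC=C(C)C)c2)n1`: 690 nM
- compound 2, `COCc1ccnc(Nc2ccc(Cl)c(OCC=C(C)C)c2)n1`: > 25000 nM

In an ADME assay on MT2 cells (Homo sapiens) for cytotoxicity (on this read-out lower numbers stand for higher toxicity in this test and higher numbers for lower toxicity in this test), compound 1 gives 690 nM. For compound 2 only a limit of this assay is known, > 25000 nM, so compound 2 stands at the least toxic end of the numbers shown, at the limit of > 25000 nM in this assay, at which 1 of the 2 values shown sits. For the measured compounds named here, the single measured step, an at least 36-fold higher number from compound 1 to compound 2 (1.55 log units; beyond the scatter), is the only one and it concerns a different exchange on the aromatic carbon.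

Compound 3, `CC(C)=CCOc1cc(Nc2nccc(CO)n2)ccc1Cl`, has not been measured. It differs from compound 2 by hydrogen in place of methyl on an oxygen on a saturated carbon. Going by the values given here, no measured step covers the methoxymethyl to hydroxymethyl exchange, so the expectation rests on where compound 2 stands: at a limit, with no number above it to move toward. For compound 3 the estimate is 25000 nM, within 8000 nM to 80000 nM, which means an expected step of a number no higher from compound 2 to compound 3 (the limit leaves the size open), that is, none beyond the scatter, and a fair chance that this assay again reports only a limit for compound 3.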

Compound 3, half-maximal cytotoxic concentration: 220 nM
Beside the measured number, compound 3's estimate is 110-fold (2.06 log units) above it; measured number below the stated range.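

In this assay, the methoxymethyl to hydroxymethyl exchange is far from silent: hydrogen in place of methyl on this oxygen gives an at least 110-fold lower number from compound 2 to compound 3 (2.05 log units; beyond the scatter), so the read-out at this aromatic carbon turns on that single methyl and not merely on an oxygen-bearing chain being present. Compound 2 gives > 25000 nM, which is a limit of the assay and not a number: the limit of > 25000 nM in this assay, at which 1 of the 3 values shown sits. Hydroxymethyl in place of methylamino gives a 3.1-fold lower number from compound 1 to compound 3 (0.50 log units; beyond the scatter), so among the three groups on this carbon, methoxymethyl in compound 2 is the one that stands apart, while the other two both give low numbers, and the earlier pair alone could not show that this separation lies with the methyl on oxygen.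

As far as these compounds go, the true size of the step from methoxymethyl to hydroxymethyl stays open, since one end of it is a limit. Also open, from the compounds shown here alone, is whether the free hydroxy group itself goes with the low numbers, which an aminomethyl, a carboxylic acid, an ethoxymethyl or a plain methyl group on the same carbon would help to separate.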